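The source may hold more compounds than are shown below. What is called first, only, known or untested is meant among the compounds shown, and "the series" means these compounds.

Compound 1, `CCN(CC)c1ccc2nc(-c3ccccc3OC(F)(F)F)[nH]c(=O)c2c1`: in a functional assay on HCT-15 cells (Homo sapiens) for cytotoxicity, read by MTT assay, with a stated time of 2 days (a higher number here means a weaker inhibitor, a lower number a stronger inhibitor), compound 1 gives 1710 nM.
Compound 2, `CCN(CC)c1ccc2nc(-c3ccccc3C(F)(F)F)[nH]c(=O)c2c1`: in this assay compound 2 gives 280 nM.
Compound 3, `Cc1ccc2c(=O)[nH]c(-c3cccc(OC(F)(F)F)c3)nc2c1`: in this assay compound 3 reaches only a limit of the assay, > 50000 nM.

Compound 4, `Cc1ccc2c(=O)[nH]c(-c3cccc(C(F)(F)F)c3)nc2c1`, has not yet been measured. From compound 1 to compound 2 the change is trifluoromethyl in place of trifluoromethoxy on an aromatic carbon, and in this assay it brought a 6.1-fold lower number from compound 1 to compound 2 (0.79 log units; beyond the scatter). The same kind of change separates compound 3 from compound 4, (trifluoromethyl in place of trifluoromethoxy on an aromatic carbon), though the place is not the same: here the group sits meta to a large group, whereas before it sat ortho to a large group. The difference between the two cores is not broken down here. Since compound 3 stands at the limit of > 50000 nM in this assay, at which 1 of the 3 values shown sits, the starting point is itself uncertain. Resting on the earlier step of a 6.1-fold lower number from compound 1 to compound 2 (0.79 log units; beyond the scatter), the step expected in this assay is an at least 1.2-fold lower number from compound 3 to compound 4 (0.09 log units; that floor lies within the scatter). Compound 4 is estimated at 40000 nM, between 10000 nM and 150000 nM.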

Compound 4, half-maximal inhibitory concentration: > 50000 nM
Compound 4 was reported as a limit; the forecaster's own chance of this, stated with the estimate: 60%; middle value at least 1.2-fold (0.09 log units) from the limit.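

In this assay compound 3 gives only a limit, > 50000 nM. Compound 4 also gives only a limit, > 50000 nM, and the step between these two compounds cannot be read. The compounds shown leave open whether trifluoromethyl or trifluoromethoxy gives the lower number at this place on this core.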